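Moving a Methyl Group on the Aryl Amide

The compounds below may be only part of what the source reports. "The series", "measured", "known", "first", "only" and "open" are said of these compounds alone.

Measured so far:
compound 1, `O=C(NC(=S)NNc1ncnc2ccccc12)c1ccccc1F`: 2510 nM
compound 2, `COc1ccccc1C(=O)NC(=S)NNc1ncnc2ccccc12`: a limit of the assay, > 50000 nM
compound 3, `Cc1ccc(C(=O)NC(=S)NNc2ncnc3ccccc23)cc1`: 10100 nM

The three measured compounds share one core and differ only in the aryl group attached to the carbonyl carbon. In a functional assay on KB cells (Homo sapiens) for cytotoxicity, read by MTT assay, with a stated time of 72 h (on this read-out lower numbers stand for stronger inhibition and higher numbers for weaker inhibition), compound 1 gives 2510 nM. Compound 3 gives 10100 nM, the highest of the two plain numbers; the step of a 4.0-fold higher number from compound 1 to compound 3 (0.60 log units; beyond the scatter) is beyond the scatter. Compound 2 reaches only a limit of this assay, > 50000 nM (the limit of > 50000 nM in this assay, at which 1 of the 3 values shown sits). The step of an at least 19-fold higher number from compound 1 to compound 2 (1.29 log units; beyond the scatter) and the step of an at least 4.9-fold lower number from compound 2 to compound 3 (0.69 log units; beyond the scatter) show that exchanging this aryl group has moved the number by modest to large amounts in both directions.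

Compound 4, `Cc1ccccc1C(=O)NC(=S)NNc1ncnc2ccccc12`, has not yet been measured. It differs from compound 3 by 2-methylphenyl in place of 4-methylphenyl on a carbonyl carbon. Compound 1 with its 2-fluorophenyl and compound 2 with its 2-methoxyphenyl mark the two extremes seen, so the exchange bears on this assay but gives no clear direction. Compound 4 is therefore expected to sit near compound 3, with an estimate of 12000 nM (range 3000 nM to 50000 nM), a step of a 1.2-fold higher number from compound 3 to compound 4 (0.07 log units; within the scatter) that may stay within the scatter.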

Compound 4, half-maximal inhibitory concentration: 2770 nM
The estimate for compound 4 lay 4.3-fold (0.64 log units) above the measured number; measured number outside the range, below it.
By their numbers in this assay, from the lowest: compounds 1 and 4 (each within the scatter of the next); then compound 3. At a limit, above all of these: compound 2.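

In this assay, moving the methyl group matters even though the atoms stay the same: 2-methylphenyl in place of 4-methylphenyl gives a 3.6-fold lower number from compound 3 to compound 4 (0.56 log units; beyond the scatter). On the same aromatic carbon, methyl in place of fluoro gives a 1.1-fold higher number from compound 1 to compound 4 (0.04 log units; within the scatter), so these two groups cannot be told apart here, whereas methyl in place of methoxy gives an at least 18-fold lower number from compound 2 to compound 4 (1.25 log units; beyond the scatter). That last step is only a bound, since compound 2 stands at a limit of the assay: the limit of > 50000 nM in this assay, at which 1 of the 4 values shown sits.

The compounds shown leave open how an amine, a chloro group or a carboxylic acid in place of the methyl group of compound 4 would behave. They also give no reason why methyl and fluoro match while methoxy stands so far apart.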